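The compounds below may be only part of what the source reports. "The series", "measured", "known", "first", "only" and "open" are said of these compounds alone.

Measured in a functional assay on the whole organism (strain Sprague-Dawley) for inhibition, with Rattus norvegicus as the target, with a stated time of 10 min; a lower number here means that less compound is needed, a higher number that more compound is needed for the effect:
- Compound 1 `O=C(O)c1cnc(-c2ccccc2)[nH]c1=O`: 50 mg/kg
- Compound 2 `O=C(O)c1cnc(-c2ccccc2F)[nH]c1=O`: 5 mg/kg
- Compound 3 `O=C(O)c1cnc(-c2ccccc2Cl)[nH]c1=O`: not yet measured

Of the two measured compounds, compound 2 has the lower number, at 5 mg/kg. Among the compounds with values here, the only measured step is a 10-fold lower number from compound 1 to compound 2 (1.00 log units; beyond the scatter), with fluoro in place of hydrogen on an aromatic carbon. Within the data shown here, compound 3 keeps the core and changes only that group: chloro in place of fluoro on an aromatic carbon. This is chloro in place of fluoro on an aromatic carbon.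

Among the measured compounds shown here, no measured step covers this exchange. The earlier step bears on it only indirectly, showing that a change at this place can move the number in this assay. It gives no direction for the new exchange, so a change beyond the scatter is not expected, though a shift of up to that earlier size remains possible. The expected change is a 1.2-fold higher number from compound 2 to compound 3 (0.08 log units; within the scatter). Compound 3 is estimated at 6 mg/kg, with an expected range of 1.5 mg/kg to 25 mg/kg.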

Compound 3, dose for 50% inhibition: 5 mg/kg
Compound 3: middle estimate off by 1.2-fold (0.08 log units), on the high side; measured number inside the range.
By their numbers in this assay, from the lowest: compounds 2 and 3 (each within the scatter of the next); then compound 1.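

In this assay, chloro in place of fluoro on this aromatic carbon, ortho to a large group, gives no change at the digits printed from compound 2 to compound 3 (within the scatter), so the two halogens cannot be told apart at this place. Chloro in place of hydrogen gives a 10-fold lower number from compound 1 to compound 3 (1.00 log units; beyond the scatter), a step of the same printed size as the one for fluoro, a 10-fold lower number from compound 1 to compound 2 (1.00 log units; beyond the scatter), which shows that the lower number is not tied to fluoro alone. No measurement offered here speaks to the cause of this match.

Going by these compounds, whether the same number holds with bromo, methyl or methoxy on this carbon remains open, as does the outcome with a hydroxyl or an amine there. Also open, on these data alone, is whether chloro or fluoro on another carbon of the same aromatic ring would give a step of this size.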